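The source may report more compounds than this note shows. Statements on the series, on what has been measured and on what is new or still open speak of the compounds shown alone.

Measured compounds:
- Compound 1 `Cc1cc2c(c(=O)[nH]1)C(c1cn([C@H]3C[C@H](O)[C@@H](CO)O3)c(=O)[nH]c1=O)C(C#N)=C(N)O2` gives > 100000 nM in an ADME assay on HEL cells (Homo sapiens) for cytotoxicity; a higher number here means that more compound is tolerated, a lower number that less compound is tolerated; this is a limit of the assay, not a number.
- Compound 2 `Cc1cc(O)c(C(c2cn([C@H]3C[C@H](O)[C@@H](CO)O3)c(=O)[nH]c2=O)c2c(O)cc(C)[nH]c2=O)c(=O)[nH]1` gives 2100 nM in this assay.
- Compound 3 `Cc1cc(O)c(C(c2cn([C@H]3C[C@H](O)[C@@H](CO)O3)c(=O)[nH]c2=O)c2c(O)cc(C)n(C)c2=O)c(=O)n1C` gives 7700 nM in this assay.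

Compound 1 stands apart from the other two in that its result is known only as a limit (the limit of > 100000 nM in this assay, at which 1 of the 3 values shown sits), so no number for it can be ranked against compound 2 or compound 3. Going by the values given here, compound 2 and compound 3 each give a number, and the two numbers differ in favour of compound 3, though the two structures differ in more than one place and no single step between them can be drawn.

Compound 4 `CCn1c(C)cc2c(c1=O)C(c1cn([C@H]3C[C@H](O)[C@@H](CO)O3)c(=O)[nH]c1=O)C(C#N)=C(N)O2` is derived from compound 1 by one change: ethyl in place of hydrogen on an aromatic nitrogen. No measured pair among the shown compounds isolates this change, so the size of the step in this assay cannot be taken from the data. The expectation is that the step from compound 1 to compound 4 stays at or near the limit, with no change beyond the scatter, a number no higher from compound 1 to compound 4 (the limit leaves the size open). Compound 4 is therefore expected to give about 100000 nM in this assay, within a range of 30000 nM to 300000 nM.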

Compound 4, half-maximal cytotoxic concentration: > 100000 nM
Compound 4 gave a limit, no number; the forecaster's own chance of this, stated with the estimate: 60%; the middle value sits exactly at the limit.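

No step from compound 1 to compound 4 can be read, as both results in this assay are limits of the assay and not numbers: the limit of > 100000 nM in this assay, at which 2 of the 4 values shown sit.

The compounds shown leave open whether ethyl in place of hydrogen on an aromatic nitrogen changes the tolerated concentration at all, and by how much.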